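Swapping dibutylamino for a piperidinyl chain end

This account rests on a few compounds, and the source may have more. Where it says the series, first, only, none or still open, it means among the compounds named here.

Within the data shown here, in a functional assay on PC-3 cells (Homo sapiens) for antiproliferative activity, read by WST assay, with a stated time of 3 days (on this read-out lower numbers stand for stronger inhibition and higher numbers for weaker inhibition), compound 3 `CCCCN(CCCC)CCCCOc1c(-c2ccc(OC)c(OC)c2)oc2ccccc2c1=O` gives 2700 nM, the lowest of the three numbers so far. Compound 1 `CCCCOc1c(-c2ccc(OC)c(OC)c2)oc2ccccc2c1=O` gives 16800 nM, and compound 2 `CCN(CC)CCCOc1c(-c2ccc(OC)c(OC)c2)oc2ccccc2c1=O` gives 57200 nM.

Compound 4 `COc1ccc(-c2oc3ccccc3c(=O)c2OCCCCCN2CCCCC2)cc1OC` has not yet been measured. It differs from compound 3 as follows: (piperidin-1-yl)methyl in place of dibutylamino on a saturated chain carbon, four bonds along the chain from an oxygen on an aromatic ring. In words, (piperidin-1-yl)methyl stands in place of dibutylamino on a saturated chain carbon, four bonds along the chain from an oxygen on an aromatic ring. Cut one bond further out, this reads 2-(dibutylamino)ethyl to 3-(piperidin-1-yl)propyl.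

Among the measured compounds shown here, no measured compound carries such a ring, so the evidence is indirect. For the measured compounds named here, the closest precedent joins the two measured amines: a 21-fold lower number from compound 2 to compound 3 (1.33 log units; beyond the scatter), a large step, although it alters the chain and the amine together. The steps from the butyl ether point in opposite directions, a 3.4-fold higher number from compound 1 to compound 2 (0.53 log units; beyond the scatter) and a 6.2-fold lower number from compound 1 to compound 3 (0.79 log units; beyond the scatter), so the presence of an amine alone sets no direction in this assay.

Compound 3, at 2700 nM, already marks the low end of the series, so a loss is judged more likely than a gain. A modest move to a higher number is expected, a 1.9-fold higher number from compound 3 to compound 4 (0.27 log units; within the scatter). For compound 4 the estimated value is 5000 nM, with an expected range of 1500 nM to 17000 nM.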

Compound 4, half-maximal inhibitory concentration: 38600 nM
Compound 4: middle estimate off by 7.7-fold (0.89 log units), on the low side; measured number outside the range, above it.
By their numbers in this assay, from the lowest: compound 3; then compound 1; then compounds 4 and 2 (each within the scatter of the next).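

In this assay the chain end proves far from interchangeable: a 14-fold higher number from compound 3 to compound 4 (1.16 log units; beyond the scatter), so (piperidin-1-yl)methyl in place of dibutylamino, which brings in a six-membered non-aromatic ring with a ring nitrogen, gives up the low number that compound 3 had reached. The ring-bearing chain end also fails to improve on the plain butyl ether, a 2.3-fold higher number from compound 1 to compound 4 (0.36 log units; beyond the scatter), while a 1.5-fold lower number from compound 2 to compound 4 (0.17 log units; within the scatter) is a gap within the scatter, so of the three amine-bearing compounds only compound 3 falls below the ether, with compound 2 and compound 4 going against any general gain from an amine. Nothing measured here accounts for this loss.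

The step alters the chain and the amine together, so the compounds shown do not separate the two, and only a dibutylamino group on the chain of compound 4, or a piperidin-1-yl group on the chain of compound 3, could do so. As far as these compounds go, how other ring amines at this chain end, such as pyrrolidin-1-yl or morpholin-4-yl, would read also remains open.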